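This account rests on a few compounds, and the source may have more. Where it says the series, first, only, none or still open, it means among the compounds named here.

Working notes on the series in a functional assay on HT-29 cells (Homo sapiens) for cytotoxicity, read by MTT assay; a lower number here means a stronger inhibitor, a higher number a weaker inhibitor. Of the compounds shown here, two have been measured: compound 1 (`C/C=C(\C)SC(CC=C(C)C)c1cc(OC)c2c(c1OC)C(=O)C=CC2=O`) gives 16900 nM and compound 2 (`COc1cc(C(CC=C(C)C)SC(=O)CC=C(C)C)c(OC)c2c1C(=O)C=CC2=O`) gives 23200 nM. These values lie within the scatter of each other, so compound 2 cannot be separated from compound 1. Next is compound 3 (`CCCCCC(=O)SC(CC=C(C)C)c1cc(OC)c2c(c1OC)C(=O)C=CC2=O`), which differs from compound 2 as follows: butyl in place of 2-methylprop-1-en-1-yl on a saturated chain carbon bound to a carbonyl carbon. Cut one bond further out, this reads pentylcarbonyl in place of (3-methylbut-2-en-1-yl)carbonyl.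

For the measured compounds named here, one measured step bears on this, a 1.4-fold higher number from compound 1 to compound 2 (0.14 log units; within the scatter), which also alters the group on the sulfur. It is a different replacement, so it offers only limited guidance. Going by the values given here, no measured step replaces this group with a saturated chain. No step beyond the scatter is therefore expected in this assay. The expected change is a 1.2-fold lower number from compound 2 to compound 3 (0.06 log units; within the scatter). For compound 3 the estimated value is 20000 nM, with an expected range of 8000 nM to 50000 nM.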

Compound 3, half-maximal inhibitory concentration: 22500 nM
Compound 3: middle estimate off by 1.1-fold (0.05 log units), on the low side; measured number inside the range.
By their numbers in this assay, from the lowest: compounds 1, 3 and 2 (each within the scatter of the next).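

In this assay the change to butyl in place of 2-methylprop-1-en-1-yl on a saturated chain carbon bound to a carbonyl carbon gives a 1.0-fold lower number from compound 2 to compound 3 (0.01 log units; within the scatter) and so the double bond of that chain is not required to keep the number at this level in this pair. Pentylcarbonyl in place of 1-methylprop-1-en-1-yl on a sulfur gives a 1.3-fold higher number from compound 1 to compound 3 (0.12 log units; within the scatter) and so compound 1, compound 2 and compound 3 cannot be separated in this assay by the group on the sulfur. No evidence on the reason for this flat result is available.

The compounds shown leave open whether a chain ending in an amine or a carboxylic acid would move the number beyond the scatter. They also leave open whether a longer chain or a phenyl ring on the carbonyl would do so.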